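Swapping a hydroxyethoxy tail for chloro on the core

The source may hold more compounds than are shown below. What is called first, only, known or untested is meant among the compounds shown, and "the series" means these compounds.

Measured compounds:
compound 1, `C[C@@H]1CN(c2sc(C(F)(F)F)nc2-c2nc3cc(OCCO)ccc3[nH]2)CCN1C(=O)Cn1cnc2cccnc21`: 99.1 nM
compound 2, `Cc1nc(C)n(CC(=O)N2CCN(c3sc(C(F)(F)F)nc3-c3nc4cccc(C)c4[nH]3)C[C@H]2C)n1`: 376 nM
compound 3, `C[C@@H]1CN(c2sc(C(F)(F)F)nc2-c2nc3ccccc3[nH]2)CCN1C(=O)Cn1cc(C2CCN(C)CC2)cn1`: 1690 nM

The read-out is a functional assay on Venous blood for antagonist activity at C-X-C chemokine receptor type 3 (Homo sapiens), read by flow cytometry, with a stated time of 30 min, in the presence of a further agent that is not named here; on this read-out lower numbers stand for stronger inhibition and higher numbers for weaker inhibition. Among the three measured compounds, compound 1 gives the lowest number, 99.1 nM. Compound 2 lies a clear distance higher at 376 nM, and compound 3 is furthest away at 1690 nM; both gaps are beyond the usual scatter, so compound 1 stands as the most potent of the three. Compounds 2 and 3 differ from compound 1 in more than one place, so no single change can be tied to either gap.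

Compound 4, `C[C@@H]1CN(c2sc(C(F)(F)F)nc2-c2nc3cc(Cl)ccc3[nH]2)CCN1C(=O)Cn1cnc2cccnc21`, keeps everything in compound 1 except one group on the fused two-ring part of the core. The change is: chloro in place of 2-hydroxyethoxy on an aromatic carbon. A short two-carbon chain ending in a hydroxyl, with its one donor and two acceptors, is replaced by a single chlorine.

Within the data shown here, no measured pair here isolates this kind of change, so the expectation rests on compound 1 alone. A small step is expected, a 1.5-fold higher number from compound 1 to compound 4 (0.18 log units; within the scatter), not clearly beyond the scatter in either direction. Compound 4 is therefore estimated at 150 nM, with a plausible range from 40 nM to 600 nM.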

Compound 4, half-maximal inhibitory concentration: 38.5 nM
Estimate against measurement, compound 4: 3.9-fold (0.59 log units) above; measured number outside the range, below it.
By their numbers in this assay, from the lowest: compound 4; then compound 1; then compound 2; then compound 3.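

In this assay, among these compounds, replacing the 2-hydroxyethoxy tail with chloro gives a 2.6-fold lower number from compound 1 to compound 4 (0.41 log units; beyond the scatter), and it is the first change here that can be read on its own, as compound 4 and compound 1 differ in this one place. It shows that, on this aromatic carbon of the fused two-ring part of the core, the number does not depend on keeping the tail's hydrogen-bond donor and acceptors: a single chlorine, with none of them, gives a lower number in this pair. Nothing measured here explains the drop, so it stands as an observation without a known cause.

The compounds shown leave open whether the gain comes from the chlorine itself or simply from losing the tail, a question that a bare hydrogen, a fluorine, a methoxy group or an amine on the same carbon could help separate. It is also unknown whether the same swap would have a similar effect with the different groups carried by compound 2 or compound 3, which differ from compound 1 in more than one place.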